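The source may hold more compounds than are shown below. What is called first, only, known or untested is meant among the compounds shown, and "the series" means these compounds.

Working notes on a small amide series examined for tolerability in a toxicity assay on THP-1 cells (Homo sapiens) for inhibition; a higher number here means that more compound is tolerated, a lower number that less compound is tolerated. Among the measured compounds shown here, compound 1 `Cn1c(-c2ccc(Br)cc2)cnc1NC(=O)c1ccc(F)cc1` is the one member that returns a number: in this assay compound 1 gives 46000 nM. Compound 2 `COc1ccc(-c2ccc(NC(=O)c3ccc(F)cc3)nc2)cc1` reaches only the limit of this assay, reported for compound 2 as > 100000 nM. Compound 3 `COc1ccc(-c2cnc(NC(=O)c3cccc(C)c3)n2C)cc1` likewise stops at a limit, reported for compound 3 as > 100000 nM. For the measured compounds named here, compound 1 therefore stands alone as the single value among the three, the other two sitting at the limit of > 100000 nM in this assay, at which 2 of the 3 values shown sit. Going by the values given here, no pair among the measured compounds differs in just one place, so no measured step is available to lean on.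

The step of interest leads to compound 4 `Cn1c(-c2cccc(F)c2)cnc1NC(=O)c1ccc(F)cc1`, which differs from compound 1 by 3-fluorophenyl in place of 4-bromophenyl on an aromatic carbon. The rest of the shared core is untouched. Without a measured step for comparison, the expected step in this assay is a 1.4-fold higher number from compound 1 to compound 4 (0.15 log units; within the scatter), small and not clearly beyond the scatter, with the direction toward more compound tolerated only weakly favoured. Compound 4 is thus estimated at 65000 nM, within a range from 30000 nM to 100000 nM, and a reading at the limit would not surprise.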

Compound 4, half-maximal cytotoxic concentration: 58000 nM
Beside the measured number, compound 4's estimate is 1.1-fold (0.05 log units) above it, within the range that was stated.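

In this assay, the series now has its first measured step between compounds that differ in one place, and it is a 1.3-fold higher number from compound 1 to compound 4 (0.10 log units; within the scatter) at this aromatic carbon of the five-membered ring. Exchanging 4-bromophenyl for 3-fluorophenyl here therefore leaves the reading inside the usual scatter, even though the halogen and its place on the phenyl ring both change in the same step. Compound 1 and compound 4 both return numbers, whereas the remaining members stop at a limit: the limit of > 100000 nM in this assay, at which 2 of the 4 values shown sit.

This single step cannot separate the identity of the halogen from its place on the phenyl ring, and 3-bromophenyl or 4-fluorophenyl at the same position would be needed to tell these two changes apart. On these data alone, it also remains open whether a group of a different kind at this position, such as an aminomethyl-substituted phenyl or a phenyl bearing a carboxylic acid, would move the number beyond the scatter in this assay rather than leave it where the two halogenated phenyl groups do.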